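Hydroxy removal across a small antiproliferative series

This account rests on a few compounds, and the source may have more. Where it says the series, first, only, none or still open, it means among the compounds named here.

Compound 1 `COc1ccc(-c2c(Nc3cc(OC)c(OC)c(OC)c3)c3ccccc3oc2=O)cc1` gives 82300 nM in a functional assay on MCF7 cells (Homo sapiens) for antiproliferative activity, read by MTT assay, with a stated time of 48 h; a lower number here means a stronger inhibitor, a higher number a weaker inhibitor. Compound 2 `COc1ccc(-c2c(Nc3cc(OC)c(OC)c(OC)c3)c3ccc(O)cc3oc2=O)cc1` gives 56000 nM in this assay. Compound 3 `COc1ccc(-c2c(Nc3ccc(C)c(O)c3)c3ccc(O)cc3oc2=O)cc1` gives > 100000 nM in this assay, which is a limit of the assay and not a number. The step of a 1.5-fold higher number from compound 2 to compound 1 (0.17 log units; within the scatter) is hydrogen in place of hydroxy on an aromatic carbon. How the core of compound 3 differs from that of compound 2 is not broken down here. Compound 4 `COc1ccc(-c2c(Nc3ccc(C)cc3)c3ccc(O)cc3oc2=O)cc1` is not yet measured in this assay; it differs from compound 3 by hydrogen in place of hydroxy on an aromatic carbon. This is the same kind of change as from compound 2 to compound 1, but the place differs: there the hydroxy sat on a ring that is part of a fused or bridged system of two rings, meta to a fused ring and para to a fused ring, whereas here it sits ortho to a methyl group and meta to a large group. Because a 1.5-fold higher number from compound 2 to compound 1 (0.17 log units; within the scatter) lay within the scatter, compound 4 is expected to move little from compound 3, with an expected step that the limit leaves unreadable from compound 3 to compound 4. Since compound 3 sits at the limit of > 100000 nM in this assay, at which 1 of the 3 values shown sits, compound 4 is estimated at 120000 nM, between 50000 nM and 300000 nM, and most likely again reported as a limit.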

Compound 4, half-maximal inhibitory concentration: 85500 nM
Compound 4: middle estimate off by 1.4-fold (0.15 log units), on the high side; the range from low to high includes it.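

In this assay, going by these compounds, hydrogen in place of hydroxy on an aromatic carbon gives an at least 1.1-fold lower number from compound 3 to compound 4 (0.06 log units; that floor lies within the scatter) and only a floor can be read there, so the full size of this step stays unknown. Compound 3 stands at > 100000 nM as a limit of the assay and not a number. The change can therefore be carried from one core to the other only as far as the two readings allow, which shows neither that it acts alike on both cores nor that it acts differently: the same change on two cores in this assay, a 1.5-fold higher number (0.17 log units; within the scatter) from compound 2 to compound 1 and an at least 1.1-fold lower number (0.06 log units; that floor lies within the scatter) from compound 3 to compound 4; the limit leaves it open whether they differ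

The compounds shown leave open how far removing the hydroxy in the 3-hydroxy-4-methylphenyl group moves the value once the starting compound has a measured number and not a limit. They also leave open what an amine or a carboxylic acid would give in this assay at the place of either hydroxy, on the core of compound 2 or on that of compound 3.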